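The compounds below may be only part of what the source reports. "The series", "measured", "known", "first", "only" and "open" are said of these compounds alone.

Working notes on the series. Compound 1 `COc1ccc(C2N=C(SCc3ccccc3)NC(C)=C2C(=O)Nc2ccc(F)cc2)cc1OC` gives 11.8% in a functional assay on the whole organism (artery, strain albino) with Rattus norvegicus as the target, with a stated time of 240 min, at a dose of 10 mg/kg by the oral route; on this read-out lower numbers stand for less inhibition and higher numbers for more inhibition at the one dose given (going by the name of the read-out). Compound 2 `COc1ccc(C2N=C(SCc3cccc(Cl)c3)NC(C)=C2C(=O)Nc2ccc(F)cc2)cc1OC` carries chloro in place of hydrogen on an aromatic carbon and gives 14.9%; the step of a number 3.1 percentage points higher from compound 1 to compound 2 (within the scatter). Compound 3 `COc1ccc(C2N=C(SCc3ccccc3)NC(C)=C2C(=O)Nc2ccc(Br)cc2)cc1` gives 13.3%; the difference between the cores of compound 1 and compound 3 is not broken down here, and the three values stand within the scatter of one another. Compound 4 `COc1ccc(C2N=C(SCc3ccccc3Cl)NC(C)=C2C(=O)Nc2ccc(Br)cc2)cc1` differs from compound 3 by chloro in place of hydrogen on an aromatic carbon. This is the same kind of change as from compound 1 to compound 2, not the same: there the chloro entered meta to a large group, here it enters ortho to a large group. The step is expected to be a number 1.7 percentage points higher from compound 3 to compound 4 (within the scatter), resting on the earlier step of a number 3.1 percentage points higher from compound 1 to compound 2 (within the scatter), which stayed within the scatter. Compound 4 is therefore estimated at 15% in this assay, with a range from 5% to 28%.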

Compound 4, a percentage reported as inhibition, in the whole organism at one dose (the size of the read-out at that dose, not a potency): 15.4%
Estimate against measurement, compound 4: 0.4 percentage points below, and the stated range covers the measured number.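

Chloro in place of hydrogen on an aromatic carbon gives a number 2.1 percentage points higher from compound 3 to compound 4 (within the scatter). Set beside the earlier step, the change reads alike on the two cores in this assay: the same change on two cores in this assay, a number 3.1 percentage points higher (within the scatter) from compound 1 to compound 2 and a number 2.1 percentage points higher (within the scatter) from compound 3 to compound 4, 1 percentage points apart, within the scatter of two such steps This shows no difference in how the change carries from one core to the other, but it does not show that chloro has a real effect on either core, since each step stays within the scatter and the chloro does not stand at the same place in both pairs.

On the benzyl ring, the compounds shown carry only hydrogen or chloro. Going by these compounds, what an amine or a carboxylic acid would do there stays open, as does a longer chain in place of benzyl.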